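This account rests on a few compounds, and the source may have more. Where it says the series, first, only, none or still open, it means among the compounds named here.

Of the compounds shown here, three of one series have so far been tested in an ADME assay on MDCK cells (Canis lupus familiaris) for cytotoxicity, read by MTT assay, with a stated time of 72 h; a higher number here means that more compound is tolerated, a lower number that less compound is tolerated. Compound 1 `Cc1nc([N+](=O)[O-])cn1CC(=O)Nc1c(Cl)cccc1Cl` gives 396000 nM in this assay; compound 2 `Cc1nc([N+](=O)[O-])cn1CC(=O)Nc1cccc(C(F)(F)F)c1` gives 435000 nM; and compound 3 `Cc1nc([N+](=O)[O-])cn1S(=O)(=O)c1ccc(Cl)cc1` gives 578000 nM. Compound 2 holds the second highest of these three numbers, but its gaps to compound 1 and to compound 3 both lie within the scatter, so on these data the three cannot be told apart. Compound 4 `Cc1nc([N+](=O)[O-])cn1CC(=O)Nc1ccccc1` is the next to be measured. It differs from compound 2 by hydrogen in place of trifluoromethyl on an aromatic carbon. Among the measured compounds shown here, no measured pair shows this change, so nothing in the data fixes its size. The expected step is a 1.0-fold higher number from compound 2 to compound 4 (0.01 log units; within the scatter), not beyond the scatter in either direction. Compound 4 is therefore estimated at 450000 nM, with a range from 230000 nM to 850000 nM.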

Compound 4, half-maximal cytotoxic concentration: 1140000 nM
Compound 4: the middle estimate sits 2.5-fold (0.40 log units) below what was measured, outside the stated range (above it).
By their numbers in this assay, from the lowest: compounds 1, 2, 3 and 4 (each within the scatter of the next, the first and the last beyond it).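

In this assay, among the compounds shown here, hydrogen in place of trifluoromethyl gives a 2.6-fold higher number from compound 2 to compound 4 (0.42 log units; beyond the scatter), the first single change with a readable size, and it shows that this place on the aromatic ring is not indifferent to what it carries. No measurement at hand accounts for this step.

The compounds shown leave open whether the step belongs to trifluoromethyl alone or to any group at this place. A chlorine, a methoxy group or an amine on the same aromatic carbon would separate these two readings.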